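A few compounds are considered here, and "the series" means these few. Any claim that something is new, unique, unknown or untested is made for them only; others in the source may bear on it.

Measured compounds in a functional assay on MCF7 cells (Homo sapiens) for cytotoxicity, read by sulforhodamine B assay, with a stated time of 48 h; on this read-out higher numbers stand for weaker inhibition of growth and lower numbers for stronger inhibition of growth:
- compound 1, `COc1cc(/C(Cl)=C/C=C(\C#N)C(=O)c2c[nH]c3ccccc23)cc(OC)c1OC`: 94300 nM
- compound 2, `N#C/C(=C\C=C(/Cl)c1ccc(Br)cc1)C(=O)c1c[nH]c2ccccc12`: 81500 nM

For the measured compounds named here, both compounds share the same core and differ in the aryl ring at the chlorovinyl end; they differ in more than one place, so no single step is drawn between them. In this assay compound 1 gives 94300 nM and compound 2 gives 81500 nM; the two numbers lie within the usual scatter of each other, and compound 1 cannot be set apart from compound 2 on these data. Both values sit in the weak range of the read-out.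

Compound 3, `COc1ccc(/C(Cl)=C/C=C(\C#N)C(=O)c2c[nH]c3ccccc23)cc1OC`, keeps the core of compound 1 and differs from it only in the aryl ring: hydrogen in place of methoxy on an aromatic carbon.

Going by the values given here, no measured pair isolates the loss of one methoxy group, so the direction of the step is open. With both measured compounds giving weak and closely similar numbers, the step from compound 1 to compound 3 is expected to be small, a 1.0-fold lower number from compound 1 to compound 3 (0.02 log units; within the scatter), not beyond the scatter in either direction. For compound 3 in this assay the estimate is 90000 nM, with a range from 40000 nM to 200000 nM, the range wide on both sides.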

Compound 3, concentration for total growth inhibition: > 100000 nM
Compound 3 was reported as a limit; the forecaster's own chance of this, stated with the estimate: 20%; middle value at least 1.1-fold (0.04 log units) from the limit.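

In this assay compound 3 gives > 100000 nM, which is a limit of the assay and not a number. Hydrogen in place of methoxy, on the aromatic carbon ortho to a methoxy group and meta to a large group, gives an at least 1.0-fold higher number from compound 1 to compound 3 (0.02 log units; that floor lies within the scatter), so this first single-place change in the series shows no stronger inhibition of growth on losing this methoxy group. The true size of the step cannot be read because the result for compound 3 is a limit, and the printed floor alone does not place the change beyond the scatter: the limit of > 100000 nM in this assay, at which 1 of the 3 values shown sits.

From the compounds shown here alone, whether this methoxy group contributes anything to the growth inhibition of compound 1 stays open, as a step within the scatter and one well beyond it both fit these data. Also open, going by these compounds, is whether a different group on this aromatic carbon, such as a hydroxyl, an amine or a longer alkoxy chain, would bring the number out of the weak range seen so far.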